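A few compounds are considered here, and "the series" means these few. Any claim that something is new, unique, unknown or untested is made for them only; others in the source may bear on it.

Compound 1 `Clc1ccc(-c2csc(N3N=C(c4ccc(N5CCCCC5)cc4)CC3c3ccc(Cl)cc3)n2)cc1` in a functional assay on A549 cells (Homo sapiens) for antiproliferative activity, read by MTT assay, with a stated time of 72 h; a lower number here means a stronger inhibitor, a higher number a weaker inhibitor: 46400 nM
Compound 2 `Clc1ccc(C2CC(c3ccc(N4CCCCC4)cc3)=NN2c2nc(-c3ccc(Br)cc3)cs2)cc1` in this assay: 39700 nM

Among the compounds with values here, of these two numbers, compound 2 carries the smaller one, yet the single step between them, a 1.2-fold lower number from compound 1 to compound 2 (0.07 log units; within the scatter), stays within the scatter, so the two compounds count as level. Compound 3 `N#Cc1ccc(-c2csc(N3N=C(c4ccc(N5CCCCC5)cc4)CC3c3ccc(Cl)cc3)n2)cc1` has not yet been measured; it differs from compound 2 by cyano in place of bromo on an aromatic carbon. Within the data shown here, no measured step exchanges a halogen for a cyano group, so the bromo-for-chloro step is only a loose guide here. The step from compound 2 to compound 3 is therefore expected to be a 1.0-fold higher number from compound 2 to compound 3 (0.00 log units; within the scatter), with no shift beyond the scatter. Compound 3 is estimated at 40000 nM, with a range from 15000 nM to 110000 nM.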

Compound 3, half-maximal inhibitory concentration: 11200 nM
The estimate for compound 3 lay 3.6-fold (0.55 log units) above the measured number; the measured number lies below the stated range.
By their numbers in this assay, from the lowest: compound 3; then compounds 2 and 1 (each within the scatter of the next).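

Exchanging one halogen for the other left the compounds level in this assay, but replacing the halogen with cyano gives a 3.5-fold lower number from compound 2 to compound 3 (0.55 log units; beyond the scatter) and, starting from the chloro compound, a 4.1-fold lower number from compound 1 to compound 3 (0.62 log units; beyond the scatter) as a matching result. This place on the ring, para to a large group, therefore does respond to what sits there, although both steps are modest and cyano is the only non-halogen shown. Nothing measured here explains why the cyano group gives the lower number.

On these data alone, whether a smaller group such as fluoro, or an amine or a carboxylic acid, would lower the number further remains open. So does whether the cyano step would hold in other cell lines.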